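The compounds below may be only part of what the source reports. "The series", "measured", "known", "first", "only" and "open" are said of these compounds alone.

Compound 2 is `O=c1c(Br)cccc(Br)c1O`. In an ADME assay on Huh-7 cells (Homo sapiens) for cytotoxicity (on this read-out higher numbers stand for lower toxicity in this test and lower numbers for higher toxicity in this test), compound 2 gives 92700 nM. Within the data shown here, that is the only actual number among the values gathered so far; the other value is a limit. Compound 1 is `O=c1c(CN2CCC(O)CC2)cc(CN2CCC(O)CC2)cc(CN2CCC(O)CC2)c1O`. In this assay compound 1 gives > 250000 nM, which is a limit of the assay and not a measured number, namely (the limit of > 250000 nM in this assay, at which 1 of the 2 values shown sits). Compound 3 is `O=c1ccccc(Br)c1O`. It differs from compound 2 in one place: hydrogen in place of bromo on an aromatic carbon. Among the measured compounds shown here, no step between two measured compounds is available to show how large such a change can be in this assay, so the expectation rests on compound 2 alone. The step from compound 2 to compound 3 is expected to be a 1.4-fold higher number from compound 2 to compound 3 (0.15 log units; within the scatter), probably small and within the scatter or pointing toward lower toxicity. Compound 3 is therefore estimated at 130000 nM, in a range from 45000 nM to 400000 nM.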

Compound 3, half-maximal cytotoxic concentration: 85200 nM
Compound 3: middle estimate off by 1.5-fold (0.18 log units), on the high side; the measured number falls inside the stated range.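

In this assay, putting hydrogen in place of this one bromo group gives a 1.1-fold lower number from compound 2 to compound 3 (0.04 log units; within the scatter). Among these compounds, this is the first step between two measured compounds in this test, and it shows that at this place, two ring bonds from the ring atom that bears a hydroxy group and three ring bonds from the ring atom that bears the other bromo group, the swap leaves the two compounds indistinguishable. Nothing measured here explains why this swap leaves the read-out where it is.

Still open, going by these compounds, is whether a larger group at the same place, such as an amine, a carboxylic acid or a longer chain, would move the number. The compounds shown also leave open whether replacing the other bromo group would be equally uneventful.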